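This account rests on a few compounds, and the source may have more. Where it says the series, first, only, none or still open, it means among the compounds named here.

In a functional assay on HeLa cells (Homo sapiens) for inhibition (on this read-out higher numbers stand for weaker inhibition and lower numbers for stronger inhibition), compound 1 `CC(C)=CCC/C(C)=C/C[C@]12C[C@@H](CC=C(C)C)C(C)(C)[C@](CC=C(C)C)(C(=O)C(C(=O)c3ccc(O)c(O)c3)=C1O)C2=O` gives 11.7 ug/mL. Of the two numbers recorded, this is the lower one, but compound 2 `CC(C)=CC[C@@H]1C[C@]2(CC=C(C)C)C(=O)[C@@](CC=C(C)C)(C(=O)C(C(=O)c3ccccc3)=C2O)C1(C)C` gives 12 ug/mL in this assay, and the gap between the two lies within the scatter of the measurement, so the two compounds cannot be told apart on this read-out. Compound 3 `CC(C)=CCC/C(C)=C/C[C@]12C[C@@H](CC=C(C)C)C(C)(C)[C@](C/C=C(\C)CCC=C(C)C)(C(=O)C(C(=O)c3ccc(O)c(O)c3)=C1O)C2=O` has not yet been measured in this assay. It differs from compound 1 in a single place: 3-methylbut-2-en-1-yl in place of hydrogen on a saturated chain carbon bound to a double-bonded chain carbon. Within the data shown here, no measured pair shows this change, so nothing in the data fixes its size. The step in this assay is estimated as small, probably not beyond the scatter, with at most a slight move toward a lower number: a 1.3-fold lower number from compound 1 to compound 3 (0.11 log units; within the scatter). Compound 3 is therefore expected to give about 9 ug/mL in this assay, with a range from 4 ug/mL to 20 ug/mL.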

Compound 3, half-maximal inhibitory concentration: > 20 ug/mL
Compound 3 ended at the assay's limit; the forecaster's own chance of this, stated with the estimate: 5%; middle value at least 2.2-fold (0.34 log units) away from the limit.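

On a saturated chain carbon bound to a double-bonded chain carbon, putting 3-methylbut-2-en-1-yl in place of hydrogen turns 3-methylbut-2-en-1-yl into 3,7-dimethylocta-2,6-dien-1-yl, and in this assay this gives an at least 1.7-fold higher number from compound 1 to compound 3 (0.23 log units; that floor lies within the scatter). Among these compounds, no earlier pair of compounds spoke to this position, and this first reading gives no sign that the longer chain strengthens inhibition. The step is only a floor and its full size stays unknown, because the result for compound 3 is a limit and not a number: the limit of > 20 ug/mL in this assay, at which 1 of the 3 values shown sits.

As far as these compounds go, how far compound 3 really lies from compound 1 remains open. So does whether a shorter chain at this place, such as an ethyl group, or a chain ending in an amine or a carboxylic acid, would keep the inhibition of compound 1.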